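The source may hold more compounds than are shown below. What is called first, only, known or untested is meant among the compounds shown, and "the series" means these compounds.

Working notes on the series. Every compound shares the core of compound 1 `Cc1nc(-c2ccc(C(F)(F)F)cc2)sc1CNc1ccc(C(=O)O)cc1` and differs only in the group on an aromatic carbon of a six-membered aromatic ring of carbon only, para to a large group. In a functional assay on CHO cells for agonist activity at Free fatty acid receptor 1 (Homo sapiens) (a higher number here means that more compound is needed for the effect, a lower number that less compound is needed), compound 1 gives only a limit, < 10000 nM. Compound 2 `Cc1nc(-c2ccc(C(F)(F)F)cc2)sc1CNc1ccc(C(C)CC(=O)O)cc1` gives 58.9 nM in this assay. Compound 3 `Cc1nc(-c2ccc(C(F)(F)F)cc2)sc1CNc1ccc(CCC(=O)NC(C)C)cc1` gives 100 nM in this assay, the higher of the two readable numbers, but the step of a 1.7-fold higher number from compound 2 to compound 3 (0.23 log units; within the scatter) is within the scatter, so the two are not ordered. The steps a step that the limit leaves unreadable from compound 1 to compound 2 and a step that the limit leaves unreadable from compound 1 to compound 3 have no readable size because compound 1 sits at the limit of < 10000 nM in this assay, at which 1 of the 3 values shown sits.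

Compound 4 `Cc1nc(-c2ccc(C(F)(F)F)cc2)sc1CNc1ccc([C@H]2C[C@@H]2C(=O)N(C)C)cc1` is not yet measured. The change is 2-(dimethylcarbamoyl)cyclopropyl in place of 2-(isopropylcarbamoyl)ethyl on an aromatic carbon. For the measured compounds named here, the one readable step, a 1.7-fold higher number from compound 2 to compound 3 (0.23 log units; within the scatter), exchanged an acid for an amide on an open chain and stayed within the scatter; no measured step closes the chain into a three-membered ring or removes the amide hydrogen, so the direction is unsupported. Compound 4 is expected near 150 nM, with a range from 40 nM to 600 nM. The expected step is a 1.5-fold higher number from compound 3 to compound 4 (0.18 log units; within the scatter), likely within the scatter.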

Compound 4, half-maximal effective concentration: 66.1 nM
Compound 4: middle estimate off by 2.3-fold (0.36 log units), on the high side; the range from low to high includes it.
By their numbers in this assay, from the lowest: compounds 2, 4 and 3 (each within the scatter of the next).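

In this assay, the step that closes the open chain into a three-membered ring, adds 2 defined stereocentres and goes from 1 hydrogen-bond donor to 0 gives a 1.5-fold lower number from compound 3 to compound 4 (0.18 log units; within the scatter). The exchange of 1-(carboxymethyl)ethyl for 2-(dimethylcarbamoyl)cyclopropyl gives a 1.1-fold higher number from compound 2 to compound 4 (0.05 log units; within the scatter), so compounds 2, 3 and 4 are not ordered, and at this position a carboxylic acid is not needed for a readable number in this series. Compound 1 gives only a limit, and none of its steps can be read: the limit of < 10000 nM in this assay, at which 1 of the 4 values shown sits.

The ring and the loss of the amide hydrogen arrive together in compound 4, so their separate contributions remain unresolved. Also open, as far as these compounds go, are the other stereoisomers of the cyclopropyl group, and a carboxylic acid in place of the dimethylcarbamoyl group on that ring.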